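Swapping the azetidine for a pyrimidine on a shared core

The source may report more compounds than this note shows. Statements on the series, on what has been measured and on what is new or still open speak of the compounds shown alone.

Three compounds built on one shared core differ only in the group attached to an aromatic carbon. Compound 1 `OC1CN(c2nccnc2OC2CN(c3ccc4ccccc4n3)C2)C1` carries 3-hydroxyazetidin-1-yl there, and in a physicochemical assay for solubility, in phosphate buffer, at pH 7.4 (on this read-out higher numbers stand for higher solubility and lower numbers for lower solubility), compound 1 gives 41000 nM, the lowest of the three values. Compound 2 `COCC1CCN(c2nccnc2OC2CN(c3ccc4ccccc4n3)C2)CC1` gives 53000 nM, so that a 1.3-fold higher number from compound 1 to compound 2 (0.11 log units; within the scatter). Compound 3 `c1ccc(-c2nccnc2OC2CN(c3ccc4ccccc4n3)C2)nc1` gives 349000 nM; here an 8.5-fold higher number from compound 1 to compound 3 (0.93 log units; beyond the scatter) and a 6.6-fold higher number from compound 2 to compound 3 (0.82 log units; beyond the scatter).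

Compound 4 `c1ccc2nc(N3CC(Oc4nccnc4-c4cncnc4)C3)ccc2c1` has not yet been measured in this assay. Relative to compound 1 the change is pyrimidin-5-yl in place of 3-hydroxyazetidin-1-yl on an aromatic carbon. The step from compound 1 to compound 3 bears most directly on this, since both replacements remove the same 3-hydroxyazetidin-1-yl and bring in a six-membered aromatic ring; the step from compound 2 to compound 3 points the same way. On that basis a rise beyond the scatter is expected, of about a 6.1-fold higher number from compound 1 to compound 4 (0.79 log units; beyond the scatter). Compound 4 is therefore estimated at 250000 nM, with a range from 80000 nM to 700000 nM.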

Compound 4, solubility: 254000 nM
Compound 4: middle estimate off by 1.0-fold (0.01 log units), on the low side; low and high end bracket the measured number.
By their numbers in this assay, from the lowest: compounds 1 and 2 (each within the scatter of the next); then compounds 4 and 3 (each within the scatter of the next).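

In this assay, the gain seen with pyridin-2-yl at this aromatic carbon is not unique to that group, since pyrimidin-5-yl in place of 3-hydroxyazetidin-1-yl gives a 6.2-fold higher number from compound 1 to compound 4 (0.79 log units; beyond the scatter) and in place of 4-(methoxymethyl)piperidin-1-yl gives a 4.8-fold higher number from compound 2 to compound 4 (0.68 log units; beyond the scatter) on the same core. The two six-membered aromatic groups cannot be told apart here, as the swap between them gives a 1.4-fold lower number from compound 3 to compound 4 (0.14 log units; within the scatter) and so stays inside the noise of the measurement. Nothing shown accounts for these differences.

The compounds shown leave open whether a plain phenyl ring, with no ring nitrogen, would read like compound 3 and compound 4 or like compound 1 and compound 2. They also leave open where an open-chain amine or a carboxylic acid at this carbon would fall.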